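This account rests on a few compounds, and the source may have more. Where it says the series, first, only, none or still open, it means among the compounds named here.

Compound 1 `CC1=C(C(=O)Nc2ccc(F)cc2)C(c2ccc([N+](=O)[O-])cc2)N=C(SCc2ccccc2Cl)N1`: 18.5%
Compound 2 `CC1=C(C(=O)Nc2ccc(F)cc2)C(c2ccc([N+](=O)[O-])cc2)N=C(SCc2cccc(Cl)c2)N1`: 18.5%
Compound 3 `CC1=C(C(=O)Nc2ccc([N+](=O)[O-])cc2)C(c2ccc(Br)cc2)N=C(SCc2ccccc2Cl)N1`: 16.9%

All three were tested in a functional assay on the whole organism (artery, strain albino) with Rattus norvegicus as the target, with a stated time of 300 min, at a dose of 10 mg/kg by the oral route; a lower number here means less inhibition, a higher number more inhibition at the dose given (going by the name of the read-out). Compound 2 differs from compound 1 only by 3-chlorophenyl in place of 2-chlorophenyl on a saturated chain carbon bound to a sulfur, and the step of no change at the digits printed from compound 1 to compound 2 (within the scatter). Compound 3 carries a different core; the difference between the core of compound 3 and the core of compound 1 is not broken down here. In this assay compound 3 gives 16.9%, and the gaps to compound 1 and compound 2 are within the scatter.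

Compound 4 `CC1=C(C(=O)Nc2ccc([N+](=O)[O-])cc2)C(c2ccc(Br)cc2)N=C(SCc2cccc(Cl)c2)N1` has not yet been measured. It differs from compound 3 by 3-chlorophenyl in place of 2-chlorophenyl on a saturated chain carbon bound to a sulfur, the same change as from compound 1 to compound 2. Because that step was no change at the digits printed from compound 1 to compound 2 (within the scatter), the step from compound 3 to compound 4 is expected to be a number 0.1 percentage points higher from compound 3 to compound 4 (within the scatter). Compound 4 is therefore estimated at 17%, between 8% and 26%.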

Compound 4, a percentage reported as inhibition, in the whole organism at one dose (the size of the read-out at that dose, not a potency): 9.2%
Compound 4: the middle estimate sits 7.8 percentage points above what was measured, and the stated range covers the measured number.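

In this assay, 3-chlorophenyl in place of 2-chlorophenyl gives a number 7.7 percentage points lower from compound 3 to compound 4 (within the scatter). Set beside the same change on the other core, this step does not stand apart: the same change on two cores in this assay, no change at the digits printed (within the scatter) from compound 1 to compound 2 and a number 7.7 percentage points lower (within the scatter) from compound 3 to compound 4, 7.7 percentage points apart, within the scatter of two such steps

On these two cores, then, the change can be carried across with neither step leaving the scatter, but two pairs tested at a single dose do not show that it would behave the same way on any further core.

The compounds shown leave open how this assay would respond if a methoxy group or a nitrile took the place of the chlorine. The same holds for an amine or a longer chain in place of the whole chlorobenzyl group.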